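This account rests on a few compounds, and the source may have more. Where it says the series, first, only, none or still open, it means among the compounds named here.

Working notes on the series in an assay on isolated protein for displacement of a labelled ligand from metabotropic glutamate receptor 5 (Homo sapiens), with a stated time of 60 min, tested at 1 uM; on this read-out higher numbers stand for more inhibition at the one concentration tested (going by the name of the read-out) and lower numbers for less inhibition. Compound 1 `CC1CCN(c2c(S(=O)(=O)c3cc(Cl)cc(Cl)c3)cnc3ccc(Cl)cc23)CC1` gives 88%. Compound 2 `CC1CCN(c2c(S(=O)(=O)c3cccc(Cl)c3)cnc3ccc(Cl)cc23)CC1` gives 92%, and the step of a number 4 percentage points higher from compound 1 to compound 2 (within the scatter) lies within the scatter. Compound 3 `CC1CCN(c2c(S(=O)(=O)c3ccc(F)cc3)cnc3ccc(F)cc23)CC1` gives 87%; this number sits at the low edge of the three, but its gaps to compound 1 and to compound 2 are both within the scatter, so no ranking among the three can be drawn from these values.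

Compound 4 `CC1CCN(c2c(S(=O)(=O)c3ccc(F)cc3)cnc3ccc(Cl)cc23)CC1` has not been measured. It differs from compound 3 by chloro in place of fluoro on an aromatic carbon. Among the measured compounds shown here, the only measured one-place step is the halogen change on a different ring, from compound 1 to compound 2, and it stayed within the scatter. For the measured compounds named here, no measured step exchanges chloro for fluoro at the place in question; compound 1 and compound 3 also differ at more than one place, so only their two values can be compared, and they lie within the scatter of each other. The expectation is therefore a step of a number 1 percentage points higher from compound 3 to compound 4 (within the scatter) no larger than the scatter. Compound 4 is expected to give about 88%, within a range from 78% to 96%.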

Compound 4, a percentage reported as inhibition, at one concentration (the size of the read-out at that concentration, not a potency): 89%
Estimate against measurement, compound 4: 1 percentage points below; low and high end bracket the measured number.
By their numbers in this assay, from the lowest: compounds 3, 1, 4 and 2 (each within the scatter of the next).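

In this assay, the exchange of fluoro and chloro on an aromatic carbon of the shared core now has its own one-place step, and it gives a number 2 percentage points higher from compound 3 to compound 4 (within the scatter), so these two halogens cannot be told apart at this position. The group on the sulfonyl sulfur can now be read in the same way: 4-fluorophenyl in place of 3-chlorophenyl gives a number 3 percentage points lower from compound 2 to compound 4 (within the scatter), and 4-fluorophenyl in place of 3,5-dichlorophenyl gives a number 1 percentage points higher from compound 1 to compound 4 (within the scatter), so neither exchange separates the compounds. No evidence is at hand that bears on these steps.

As far as these compounds go, what stays open is whether an amine or a carboxylic acid on that aromatic carbon would stay within the same narrow band of numbers. From the compounds shown here alone, a read-out at one concentration gives no potency, so any ranking of these four compounds also stays open.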